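Methyl in place of methoxy on the fused ring

This account rests on a few compounds, and the source may have more. Where it says the series, first, only, none or still open, it means among the compounds named here.

The measured compounds are:
Compound 1 `O=C(Nc1nc2ccccc2s1)c1cn(-c2ccccc2)nc1-c1ccccc1`: in a functional assay on PC-3 cells (Homo sapiens) for cytotoxicity, read by MTT assay, with a stated time of 72 h (a lower number here means a stronger inhibitor, a higher number a weaker inhibitor), compound 1 gives 10400 nM.
Compound 2 `O=C(Nc1nc2ccc(F)cc2s1)c1cn(-c2ccccc2)nc1-c1ccccc1`: in this assay compound 2 gives 3250 nM.
Compound 3 `COc1ccc2nc(NC(=O)c3cn(-c4ccccc4)nc3-c3ccccc3)sc2c1`: in this assay compound 3 gives 17500 nM.

Compound 3 stands at the highest number of the three. Against compound 1 the gap is a 1.7-fold higher number from compound 1 to compound 3 (0.23 log units; within the scatter), which is within the scatter, while against compound 2 it is a 5.4-fold higher number from compound 2 to compound 3 (0.73 log units; beyond the scatter), which is beyond it. Compound 4 `Cc1ccc2nc(NC(=O)c3cn(-c4ccccc4)nc3-c3ccccc3)sc2c1` differs from compound 3 in one place: methyl in place of methoxy on an aromatic carbon. Among the compounds with values here, no measured step swaps methyl for another group, so the expectation rests on what the nearby steps show. Adding methoxy to compound 1 changed little, a 1.7-fold higher number from compound 1 to compound 3 (0.23 log units; within the scatter), and fluoro on the same ring in compound 2 gave the lowest number, a 3.2-fold lower number from compound 1 to compound 2 (0.51 log units; beyond the scatter). A small substituent at this position has therefore moved the number by at most a modest amount in either direction. For compound 4 a step of a 1.5-fold lower number from compound 3 to compound 4 (0.16 log units; within the scatter) in this assay is expected, modest and toward a lower number but not clearly beyond the scatter. Compound 4 is estimated at 12000 nM, with a range from 5000 nM to 30000 nM.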

Compound 4, half-maximal inhibitory concentration: 15700 nM
Estimate against measurement, compound 4: 1.3-fold (0.12 log units) below; the measured number falls inside the stated range.
By their numbers in this assay, from the lowest: compound 2; then compounds 1, 4 and 3 (each within the scatter of the next).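

In this assay the exchange of methoxy for methyl gives a 1.1-fold lower number from compound 3 to compound 4 (0.05 log units; within the scatter) and so stays within the scatter, which shows that this position tolerates the loss of the oxygen, and with it the one hydrogen-bond acceptor of the methoxy group, without a readable change. Compound 4 also cannot be told apart from the unsubstituted compound, with a 1.5-fold higher number from compound 1 to compound 4 (0.18 log units; within the scatter) as the step, while fluoro separates clearly from methyl, with a 4.8-fold higher number from compound 2 to compound 4 (0.68 log units; beyond the scatter) as the step, so of the four groups now seen here, hydrogen, fluoro, methoxy and methyl, only fluoro gives a result that stands apart, and compound 2 is the strongest of the series. The data offer nothing that explains why fluoro alone differs in this way.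

On these data alone, whether this separation is particular to fluoro remains open, since chloro, nitrile or trifluoromethyl at the same place could fall with compound 2 or with the other three. An amine or a carboxylic acid at this position is equally uncharted, so the compounds shown set no limit on how far a group here can move the number.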